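The source may report more compounds than this note shows. Statements on the series, on what has been measured and on what is new or still open speak of the compounds shown alone.

Working notes on the series. The shared core is carried unchanged throughout; the variation sits on the aryl group of the double-bonded chain. Compound 1 `CN1CC[C@H](c2c(O)cc(O)c3c(=O)cc(/C=C/c4ccccc4)oc23)[C@H](O)C1` gives 58000 nM in a functional assay on PC-3 cells (Homo sapiens) for inhibition, read by MTT assay, with a stated time of 48 h; on this read-out lower numbers stand for stronger inhibition of growth and higher numbers for weaker inhibition of growth. Compound 2 `CN1CC[C@H](c2c(O)cc(O)c3c(=O)cc(/C=C/c4ccc(Cl)cc4)oc23)[C@H](O)C1` gives 31000 nM in this assay, a step of a 1.9-fold lower number from compound 1 to compound 2 (0.27 log units; within the scatter). Compound 3 `CN1CC[C@H](c2c(O)cc(O)c3c(=O)cc(/C=C/c4c(F)c(F)c(F)c(F)c4F)oc23)[C@H](O)C1` gives 2000 nM in this assay and holds the lowest number of the three, with steps of a 29-fold lower number from compound 1 to compound 3 (1.46 log units; beyond the scatter) and a 16-fold lower number from compound 2 to compound 3 (1.19 log units; beyond the scatter).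

Compound 4 `CN1CC[C@H](c2c(O)cc(O)c3c(=O)cc(/C=C/c4ccccc4F)oc23)[C@H](O)C1` has not yet been measured in this assay. It differs from compound 3 by 2-fluorophenyl in place of 2,3,4,5,6-pentafluorophenyl on a double-bonded chain carbon bound to a double-bonded chain carbon. Going by the values given here, two measured steps bear on this change: a 29-fold lower number from compound 1 to compound 3 (1.46 log units; beyond the scatter) shows what the pentafluorophenyl contributed over plain phenyl, while a 1.9-fold lower number from compound 1 to compound 2 (0.27 log units; within the scatter) shows that a single halogen on the aryl group moved the number little. With only a 2-fluorophenyl in place, the step is expected to run upward, partway back toward compound 1, and is estimated at a 13-fold higher number from compound 3 to compound 4 (1.10 log units; beyond the scatter). Compound 4 is therefore expected to give 25000 nM in this assay, within 8000 nM to 60000 nM.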

Compound 4, concentration for 50% growth inhibition: 20000 nM
Estimate against measurement, compound 4: 1.3-fold (0.10 log units) above, and the stated range covers the measured number.
By their numbers in this assay, from the lowest: compound 3; then compounds 4, 2 and 1 (each within the scatter of the next, the first and the last beyond it).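

In this assay, the 2-fluorophenyl group gives a step beyond the scatter, a 2.9-fold lower number from compound 1 to compound 4 (0.46 log units; beyond the scatter), so a single halogen on the aryl group can move the number measurably at this place on the double-bonded chain. That gain remains small beside a 10-fold higher number from compound 3 to compound 4 (1.00 log units; beyond the scatter), which shows that one fluoro does not reproduce the effect of the full 2,3,4,5,6-pentafluorophenyl group, while a 1.6-fold lower number from compound 2 to compound 4 (0.19 log units; within the scatter) leaves 2-fluorophenyl and 4-chlorophenyl unresolved from each other. Nothing at hand gives a measured reason for these steps.

As far as these compounds go, it remains open whether the number falls gradually with added fluoro groups on the phenyl or only with all five in place. Also open, from the compounds shown here alone, is how a trifluoromethyl or methoxy group on the aryl ring would compare with these halogens.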